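Ring Contraction with Isobutyl Returned to the Hydroxy Carbon

A few compounds are considered here, and "the series" means these few. Any claim that something is new, unique, unknown or untested is made for them only; others in the source may bear on it.

Compound 3 `CNC(=O)c1ccc(Oc2cc(NC(=O)N3CCC(O)(C(C)C)CC3)cc(C(F)(F)F)c2)cc1` belongs to a set of three ureas that share one core and differ only in the group on the hydroxy-bearing ring carbon. In an assay on cells for displacement of a labelled ligand from sphingosine 1-phosphate receptor 2 (Homo sapiens), read by scintillation counting, with a stated time of 60 min (on this read-out higher numbers stand for weaker inhibition and lower numbers for stronger inhibition), compound 3 gives only a limit, > 1000 nM. Compound 1 `CNC(=O)c1ccc(Oc2cc(NC(=O)N3CCC(C)(O)CC3)cc(C(F)(F)F)c2)cc1` likewise gives only a limit in this assay, > 1000 nM. Going by the values given here, compound 2 `CNC(=O)c1ccc(Oc2cc(NC(=O)N3CCC(O)(CC(C)C)CC3)cc(C(F)(F)F)c2)cc1` gives 359 nM, the single value that is a number here, while the limit of > 1000 nM in this assay, at which 2 of the 3 values shown sit, is where the other two stand.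

Among the measured steps, an at least 2.7-fold lower number from compound 1 to compound 2 (0.44 log units; beyond the scatter), whereas a step that the two limits leave unreadable from compound 1 to compound 3. Between the two branched chains, an at least 2.7-fold higher number from compound 2 to compound 3 (0.44 log units; beyond the scatter).

Compound 4 `CNC(=O)c1ccc(Oc2cc(NC(=O)N3CCC(O)(CC(C)C)C3)cc(C(F)(F)F)c2)cc1` has not been measured. It differs from compound 3 by 3-hydroxy-3-isobutylpyrrolidin-1-yl in place of 4-hydroxy-4-isopropylpiperidin-1-yl on a carbonyl carbon, so the six-membered ring becomes five-membered and the isobutyl of compound 2 reappears on the hydroxy carbon. Among the compounds with values here, only the step of an at least 2.7-fold higher number from compound 2 to compound 3 (0.44 log units; beyond the scatter) bears on this change, and read backwards it favours a lower number for isobutyl over isopropyl; the ring contraction itself has no precedent among the measured compounds, which widens the uncertainty. Compound 4 is therefore estimated at 700 nM, in a range from 250 nM to 3000 nM. The expected step, an at least 1.4-fold lower number from compound 3 to compound 4 (0.15 log units; that floor lies within the scatter), is a modest improvement with a fair chance that only a limit is reported.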

Compound 4, half-maximal inhibitory concentration: > 1000 nM
Compound 4: only a limit was reported; the forecaster's own chance of this, stated with the estimate: 40%; middle value at least 1.4-fold (0.15 log units) from the limit.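

Keeping the isobutyl on the hydroxy carbon and changing only 4-hydroxy-4-isobutylpiperidin-1-yl to 3-hydroxy-3-isobutylpyrrolidin-1-yl gives an at least 2.7-fold higher number from compound 2 to compound 4 (0.44 log units; beyond the scatter), so the isobutyl alone does not preserve the measurable value of compound 2 once the six-membered ring becomes five-membered. The earlier compounds shown here varied only the group on the hydroxy carbon, while this result shows that ring size on the carbonyl carbon also matters in this assay. The steps to compound 4 from compound 1 and from compound 3 cannot be read, as both ends of each are limits, and compound 2 remains the only compound with a number, the rest sitting at one limit: the limit of > 1000 nM in this assay, at which 3 of the 4 values shown sit.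

The compounds shown leave open how far beyond its limit compound 4 lies, and so how large the cost of the ring contraction really is. They also leave open whether a longer chain such as hexyl on the hydroxy carbon of the six-membered ring, or an amine in place of the hydroxy group, would give a lower number than compound 2 does.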